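Nitro to Methyl Swap on a Sulfonyl Aryl Ring

The source may report more compounds than this note shows. Statements on the series, on what has been measured and on what is new or still open speak of the compounds shown alone.

Compound 1 `CC1=NN(C(=O)c2ccc([N+](=O)[O-])cc2)C(c2ccccc2O)C1` is tested in a functional assay on HepG2 cells (Homo sapiens) for cytotoxicity, read by MTT assay, with a stated time of 48 h (on this read-out lower numbers stand for stronger inhibition and higher numbers for weaker inhibition), where compound 1 gives 30100 nM. Its partner compound 2 `CC1=NN(C(=O)c2ccc(C)cc2)C(c2ccccc2O)C1` carries the change (methyl in place of nitro on an aromatic carbon), and in this assay compound 2 gives 11300 nM; the step was a 2.7-fold lower number from compound 1 to compound 2 (0.43 log units; beyond the scatter). Compound 3 `O=c1oc2ccccc2cc1C1=NN(S(=O)(=O)c2ccc([N+](=O)[O-])cc2)C(c2ccccc2)C1` rests on a different core; the difference between the two cores is not broken down here. In this assay compound 3 gives "not active" (no number reported), so no number stands for it. Compound 4 `Cc1ccc(S(=O)(=O)N2N=C(c3cc4ccccc4oc3=O)CC2c2ccccc2)cc1` differs from compound 3 by methyl in place of nitro on an aromatic carbon, the same change seen between compound 1 and compound 2. Given that compound 3 gave "not active" (no number reported), and that the earlier step was a 2.7-fold lower number from compound 1 to compound 2 (0.43 log units; beyond the scatter), compound 4 is expected near 40000 nM in this assay, roughly between 12000 nM and 120000 nM, with a real chance that no number is reported.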

Compound 4, half-maximal inhibitory concentration: "not active" (no number reported)
Compound 4: no number reported, so the estimate cannot be set against anything.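

Compound 3 and compound 4 both stand without a number in this assay, so no step can be read between them. No evidence at hand bears on this result. From the compounds shown here alone, whether 4-nitrophenyl to 4-methylphenyl shifts activity on this core stays open.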